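The source may report more compounds than this note shows. Statements on the series, on what has been measured and on what is new or still open speak of the compounds shown alone.

Compound 3 `Cc1ccc(C(=O)c2c(N)sc(Br)c2CC(C)(C)C)cc1` was measured in an assay on CHO cells for displacement of a labelled ligand from adenosine receptor A1 (Homo sapiens), read by scintillation counting, tested at 10 uM (on this read-out lower numbers stand for less inhibition and higher numbers for more inhibition at the one concentration tested (going by the name of the read-out)), where compound 3 gives 1%. It stands level with compound 1 `Cc1csc(N)c1C(=O)c1ccc(Cl)cc1`, which in this assay gives 1%, and with compound 2 `CC(C)(C)Cc1c(Br)sc(N)c1C(=O)c1ccc(Cl)cc1`, which gives 1%. The only single-change step among these three, no change at the digits printed from compound 2 to compound 3 (within the scatter), lies within the scatter. Compound 4 `Cc1ccc(C(=O)c2c(N)sc(-c3ccccc3)c2CC(C)(C)C)cc1` differs from compound 3 in this way: phenyl in place of bromo on an aromatic carbon. Within the data shown here, no measured step exchanges bromo for phenyl, so the measured values supply only a low baseline that neither change made so far has shifted. Compound 4 is therefore expected to give about 5%, in a range from 0% to 25%. The step this estimate means, a number 4 percentage points higher from compound 3 to compound 4 (within the scatter), is expected to remain within the scatter.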

Compound 4, a percentage reported as inhibition, at one concentration (the size of the read-out at that concentration, not a potency): 1%
Beside the measured number, compound 4's estimate is 4 percentage points above it; measured number inside the range.
By their numbers in this assay, from the lowest: compounds 1, 2, 3 and 4 (each within the scatter of the next).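

In this assay, putting phenyl in place of bromo on the aromatic carbon next to the ring sulfur gives no change at the digits printed from compound 3 to compound 4 (within the scatter), so this position takes an aromatic ring in place of a single bromine without moving the reading off its low baseline. Nothing here accounts for this flat result.

On these data alone, whether an amine or a carboxylic acid at this position would lift the reading remains open. So does whether any change to the neopentyl group would do so.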